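The source may hold more compounds than are shown below. What is called first, only, known or untested is meant among the compounds shown, and "the series" means these compounds.

Measured compounds:
compound 1 `Nc1cc(N)c2nc(-c3ccccc3)c(Oc3ccc(Cl)c(Cl)c3)nc2c1` – 41700 nM
compound 2 `CCOC(=O)[C@H](CCC(=O)O)NC(=O)c1ccc(CNc2nc3cc(N)cc(N)c3nc2-c2ccccc2)cc1` – < 100000 nM
compound 3 `CCOC(=O)[C@H](CCC(=O)O)NC(=O)c1ccc(Sc2nc3cc(N)cc(N)c3nc2-c2ccccc2)cc1` – < 100000 nM

Three compounds that share one core were tested in a functional assay on EKVX cells (Homo sapiens) for inhibition, read by sulforhodamine B assay, with a stated time of 48 h; on this read-out lower numbers stand for higher toxicity in this test and higher numbers for lower toxicity in this test. Among the compounds with values here, compound 1 gives 41700 nM, and this is the only actual number in the set. For compound 2 the test reports a limit, < 100000 nM, rather than a number. For compound 3 the test likewise reports only a limit, < 100000 nM. Compound 1 therefore stands alone as the single measured point, while the other two sit at the limit of < 100000 nM in this assay, at which 2 of the 3 values shown sit. The two neighbours are limits. Within the data shown here, no step between two measured compounds can be drawn, and the size of any change has to be guessed rather than read off.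

Compound 4 `Nc1cc(N)c2nc(-c3ccccc3)c(NCc3ccc(F)cc3)nc2c1` differs from compound 1 in one place: (4-fluorobenzyl)amino in place of 3,4-dichlorophenoxy on an aromatic carbon. The group that leaves and the group that enters are of the same size, each with one six-membered aromatic ring of carbon only, and the place on the core is unchanged. Among the measured compounds shown here, with nothing but the single value of compound 1 to lean on, the change is expected to stay within the scatter of this assay , in no particular direction. The estimated step is a 1.0-fold lower number from compound 1 to compound 4 (0.02 log units; within the scatter). Compound 4 is expected to give about 40000 nM, in a range from 10000 nM to 120000 nM.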

Compound 4, concentration lethal to 50% of the cells: 8710 nM
Beside the measured number, compound 4's estimate is 4.6-fold (0.66 log units) above it; measured number below the stated range.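

In this assay, within the data shown here, the swap gives a 4.8-fold lower number from compound 1 to compound 4 (0.68 log units; beyond the scatter), the first step in this set that can be read as an actual measured change, and it shows that this place on the shared core can shift the read-out by more than the usual scatter. The size of the group does not settle the outcome: 3,4-dichlorophenoxy and (4-fluorobenzyl)amino have the same count of heavy atoms and each holds one six-membered aromatic ring of carbon only, yet the number falls, which on this read-out means higher toxicity in the test. The swap changes several things at once, including oxygen for nitrogen, two chlorines for one fluorine and the arrival of a hydrogen-bond donor, and nothing shown here tells which of these lies behind the step.

On these data alone, whether the nitrogen or the halogen pattern carries the change stays open, and a plain benzylamino group or a (3,4-dichlorobenzyl)amino group at the same place would begin to separate the two. As far as these compounds go, how a shorter group such as a simple amine, or a longer chain ending in a carboxylic acid, would read at this place also remains unknown.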